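This account rests on a few compounds, and the source may have more. Where it says the series, first, only, none or still open, it means among the compounds named here.

Working notes on the series in a functional assay on MT4 cells (Homo sapiens) for cytotoxicity; a lower number here means a stronger inhibitor, a higher number a weaker inhibitor. Compound 3 `N#Cc1c(N)cccc1S(=O)(=O)c1cccc(Cl)c1` stands at > 200000 nM, which is a limit of the assay and not a number. Compound 1 `COc1cccc(S(=O)(=O)c2cccc(N)c2C#N)c1` gives > 200000 nM, also a limit. Compound 2 `Cc1cccc(S(=O)(=O)c2cccc(N)c2C#N)c1` gives 179000 nM. Within the data shown here, the series so far is marked by the limit of > 200000 nM in this assay, at which 2 of the 3 values shown sit.

Compound 4 `N#Cc1c(N)cccc1S(=O)(=O)c1cccc(Br)c1` differs from compound 3 as follows: bromo in place of chloro on an aromatic carbon. The measured steps bearing on this are an at least 1.1-fold lower number from compound 1 to compound 2 (0.04 log units; that floor lies within the scatter), an at least 1.1-fold higher number from compound 2 to compound 3 (0.04 log units; that floor lies within the scatter) and a step that the two limits leave unreadable from compound 1 to compound 3. None of them is readable beyond the scatter, so no step beyond the scatter is expected in this assay, in either direction. The expected change is an at least 1.0-fold lower number from compound 3 to compound 4 (0.02 log units; that floor lies within the scatter). For compound 4 the estimate is 190000 nM, with an expected range of 100000 nM to 300000 nM.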

Compound 4, half-maximal inhibitory concentration: > 200000 nM
Compound 4: only a limit was reported; the forecaster's own chance of this, stated with the estimate: 55%; middle value at least 1.0-fold (0.02 log units) from the limit.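

Compound 4 in this assay reads only as a limit of the assay (> 200000 nM). Among these compounds, at this place, on an aromatic carbon meta to a large group, bromo adds a fourth group without a step beyond the scatter: the one readable step (an at least 1.1-fold higher number from compound 2 to compound 4 (0.04 log units; that floor lies within the scatter)) shows none, and the steps from compound 3 and from compound 1 to compound 4 cannot be read. The series remains marked by a single limit: the limit of > 200000 nM in this assay, at which 3 of the 4 values shown sit.

Going by these compounds, whether that limit hides any difference among methoxy, chloro and bromo stays open. Also open, on these data alone, is whether an amine or a carboxylic acid on this carbon would give a value below the limit.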